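A few compounds are considered here, and "the series" means these few. Any claim that something is new, unique, unknown or untested is made for them only; others in the source may bear on it.

Measured in an ADME assay on PA-1 cells (Homo sapiens) for cytotoxicity, read by MTT assay, with a stated time of 72 h; a lower number here means a stronger inhibitor, a higher number a weaker inhibitor:
- Compound 1 `COc1ccc(OC)c(C2=C(c3cc(OC)c(OC)c(OC)c3)C(=O)CC2O[SiH2]C(C)(C)C)c1`: 17 ug/mL
- Compound 2 `COc1ccc(C2=C(c3cc(OC)c(OC)c(OC)c3)C(=O)CC2OC(C)=O)cc1NC=O`: 5 ug/mL
- Compound 3 `CC(=O)OC1C/C(=N/O)C(c2ccccc2)=C1c1ccccc1`: > 100 ug/mL

Compound 3 stands at the limit of > 100 ug/mL in this assay, at which 1 of the 3 values shown sits. Its entry of > 100 ug/mL is a limit of the assay and not a number. Compound 1 and compound 2, by contrast, both have numbers, but neither differs from compound 3 in one place only.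

Compound 4 `O/N=C1/CC(O)C(c2ccccc2)=C1c1ccccc1` follows from compound 3 by a single change: hydrogen in place of acetyl on an oxygen on a saturated carbon. In words, hydrogen stands in place of acetyl on an oxygen on a saturated carbon, which reads as acetoxy to hydroxy. Among the compounds with values here, no measured pair of compounds shows this change, so any expectation for it remains open. The expectation here is of no step beyond the scatter in this assay, with compound 4 staying a weak inhibitor, and a reported limit is quite possible. The expected change is an at least 1.1-fold lower number from compound 3 to compound 4 (0.04 log units; that floor lies within the scatter). For compound 4 the estimate is 90 ug/mL, with an expected range from 35 ug/mL to 150 ug/mL.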

Compound 4, half-maximal inhibitory concentration: > 100 ug/mL
Compound 4 was reported as a limit; the forecaster's own chance of this, stated with the estimate: 55%; middle value at least 1.1-fold (0.04 log units) from the limit.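

In this assay compound 4 gives > 100 ug/mL, a limit of the assay and not a number. Compound 3 also stands at a limit, so no step between compound 3 and compound 4 can be read: the limit of > 100 ug/mL in this assay, at which 2 of the 4 values shown sit.

The compounds shown leave open whether acetoxy to hydroxy changes the value in this assay at all.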